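Aryl variation on the shared core: compound 3 to compound 4

A few compounds are considered here, and "the series" means these few. Any claim that something is new, unique, unknown or untested is made for them only; others in the source may bear on it.

Compound 3 `C=CCn1c(=O)/c(=C\c2cc(Br)ccc2F)[nH]c(=O)/c1=C\c1ccccc1OC` gives 34600 nM in a functional assay on HeLa cells (Homo sapiens) for cytotoxicity, read by CCK-8 assay, with a stated time of 72 h; a higher number here means a weaker inhibitor, a lower number a stronger inhibitor. Among the compounds with a reported number it stands highest: its nearest neighbour, compound 1 `C=CCn1c(=O)/c(=C\c2cccc(F)c2)[nH]c(=O)/c1=C\c1ccccc1OC`, gives 9100 nM in this assay, and the single-site step between them, a 3.8-fold higher number from compound 1 to compound 3 (0.58 log units; beyond the scatter), goes beyond the scatter. Compound 2 `C=CCn1c(=O)/c(=C\c2ccc(Cl)c(Cl)c2)[nH]c(=O)/c1=C\c1ccccc1OC` is reported in this assay as "not active" (no number reported), so no number is available for it.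

Compound 4 `C=CCn1c(=O)/c(=C\c2ccccc2C(F)(F)F)[nH]c(=O)/c1=C\c1ccccc1OC` is the next variation at the same position: 2-(trifluoromethyl)phenyl in place of 5-bromo-2-fluorophenyl on a double-bonded chain carbon bound to an aromatic carbon. Within the data shown here, no measured step covers this exact swap. Among the measured compounds shown here, the only step on this ring that is on record, a 3.8-fold higher number from compound 1 to compound 3 (0.58 log units; beyond the scatter), shows that replacing one halogenated aryl by another shifts the number modestly and upward; compound 2 adds that a further halogenated aryl at this position loses measurable activity altogether. Taken together, the series so far gives weak inhibition throughout and no aryl that improves on compound 1.

On that basis the step of a 1.2-fold lower number from compound 3 to compound 4 (0.06 log units; within the scatter) is expected to stay within or close to the scatter, with the direction uncertain and a real chance that no number is obtained. Compound 4 is estimated at 30000 nM in this assay, within a range of 9000 nM to 100000 nM.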

Compound 4, half-maximal inhibitory concentration: 4600 nM
Estimate against measurement, compound 4: 6.5-fold (0.81 log units) above; the measured number lies below the stated range.
By their numbers in this assay, from the lowest: compounds 4 and 1 (each within the scatter of the next); then compound 3.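

In this assay, the result with a 7.5-fold lower number from compound 3 to compound 4 (0.88 log units; beyond the scatter) shows that the number at this place, on a double-bonded chain carbon bound to an aromatic carbon, can also fall on a change of aryl; the earlier compounds had shown only a rise and the loss of a number. The step of a 2.0-fold lower number from compound 1 to compound 4 (0.30 log units; within the scatter) stays within the scatter, so 2-(trifluoromethyl)phenyl and 3-fluorophenyl cannot be told apart here, and among the compounds with numbers, compound 3 alone stands apart from the other two. Nothing measured in this series bears on what lies behind these differences.

Going by these compounds, three numbers and one compound without a number do not yet give a rule for this aryl, and it remains open whether plain phenyl would fall with compound 1 and compound 4 or with compound 3. Also open is how a phenyl carrying an amine or a carboxylic acid would read at this place, since every aryl shown here carries only halogen or trifluoromethyl.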